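Same aryl swap, second time through, in a prostate cancer cell assay

This account rests on a few compounds, and the source may have more. Where it says the series, first, only, none or still open, it means among the compounds named here.

The series rests on three measured enones bearing an arylthio group, all tested in a functional assay on DU-145 cells (Homo sapiens) for inhibition, read by trypan blue exclusion, with a stated time of 96 h; on this read-out higher numbers stand for weaker inhibition of growth and lower numbers for stronger inhibition of growth. Compound 3 `COc1ccc(/C=C(/Sc2ccc(C)cc2)C(=O)c2ccc(Cl)cc2)cc1O` gives 1000 nM in this assay, and compound 2 `COc1ccc(C(=O)/C(=C\c2ccc(OC)c(O)c2)Sc2ccc(F)cc2)cc1` gives 1000 nM in this assay, so the two stand level within the scatter; how their cores differ is not broken down here. Compound 1 `Cc1ccc(S/C(=C/c2ccc(Br)cc2)C(=O)c2ccc(Cl)cc2)cc1` gives 25000 nM in this assay. The step from compound 3 to compound 1 is a 25-fold higher number from compound 3 to compound 1 (1.40 log units; beyond the scatter), and the change it records is 4-bromophenyl in place of 3-hydroxy-4-methoxyphenyl on a double-bonded chain carbon bound to a double-bonded chain carbon.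

Compound 4 `COc1ccc(C(=O)/C(=C\c2ccc(Br)cc2)Sc2ccc(F)cc2)cc1` has not yet been measured in this assay. It relates to compound 2 by the same change, (4-bromophenyl in place of 3-hydroxy-4-methoxyphenyl on a double-bonded chain carbon bound to a double-bonded chain carbon), at a place described in the same words as before. The account therefore expects a step from compound 2 to compound 4 of about a 25-fold higher number from compound 2 to compound 4 (1.40 log units; beyond the scatter), because the matched step a 25-fold higher number from compound 3 to compound 1 (1.40 log units; beyond the scatter) is the only instance shown of this change, made on a core that compound 2 matches in potency. On that basis compound 4 is estimated at 25000 nM, with a plausible range from 8000 nM to 80000 nM, pending the actual measurement.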

Compound 4, concentration for 50% growth inhibition: > 100000 nM
Compound 4: no number, only a limit; the forecaster's own chance of this, stated with the estimate: 10%; middle value at least 4.0-fold (0.60 log units) away from the limit.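

In this assay compound 4 gives > 100000 nM, which is a limit of the assay and not a number. Putting 4-bromophenyl in place of 3-hydroxy-4-methoxyphenyl again moves the read-out towards weaker inhibition of growth, an at least 100-fold higher number from compound 2 to compound 4 (2.00 log units; beyond the scatter), so the direction of the change carries from one core to the other, but its size does not: the same change on two cores in this assay, a 25-fold higher number (1.40 log units; beyond the scatter) from compound 3 to compound 1 and an at least 100-fold higher number (2.00 log units; beyond the scatter) from compound 2 to compound 4, at least 4.0-fold (0.60 log units) apart, beyond the scatter of two such steps. As far as these compounds go, the second step is open at its upper end, so the true gap between the two steps stays unknown, and a comparison of two cores does not show which difference between them goes with that gap: the limit of > 100000 nM in this assay, at which 1 of the 4 values shown sits.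

The compounds shown leave open whether the 3-hydroxy or the 4-methoxy part of the departing group accounts for the loss, as no compound here carries only one of them. They also leave open how a phenyl bearing an amine or a carboxylic acid would stand at this place on either core.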